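The source may report more compounds than this note shows. Statements on the series, on what has been measured and on what is new or still open speak of the compounds shown alone.

Measured in an ADME assay on Huh-7 cells (Homo sapiens) for cytotoxicity, with a stated time of 72 h; on this read-out lower numbers stand for higher toxicity in this test and higher numbers for lower toxicity in this test:
- Compound 1 `CC(C)CCn1nc(-c2ccn(C)c2)c(O)c(C2=NS(=O)(=O)c3cc(NS(C)(=O)=O)ccc3N2)c1=O`: > 1000 nM
- Compound 2 `CC(C)CCn1nc(CC2CCC2)c(O)c(C2=NS(=O)(=O)c3cc(NS(C)(=O)=O)ccc3N2)c1=O`: > 33000 nM

Both entries are limits of the assay, not numbers. Compound 2 stands at the limit > 33000 nM, with no exact value. Compound 3 `CC(C)CCn1nc(CC2=CCCC2)c(O)c(C2=NS(=O)(=O)c3cc(NS(C)(=O)=O)ccc3N2)c1=O` carries cyclopent-1-en-1-yl in place of cyclobutyl on a saturated chain carbon bound to an aromatic carbon. Going by the values given here, the only measured step, a step that the two limits leave unreadable from compound 1 to compound 2, concerns a different change and gives no size to carry over. The expectation therefore starts from compound 2 at > 33000 nM, and no shift beyond the scatter is expected in this assay. The expected step is a number no higher from compound 2 to compound 3 (the limit leaves the size open). The estimate for compound 3 is 33000 nM, with an expected range of 12000 nM to 60000 nM.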

Compound 3, half-maximal cytotoxic concentration: > 33000 nM
Compound 3: a limit, no number (the forecaster's own chance of this, stated with the estimate: 75%); the middle value lies on the limit itself.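

Going by these compounds alone, compound 1, compound 2 and compound 3 all give limits of the assay, not numbers, so no step to compound 3 can be read. The compounds shown leave open where each compound's true half-maximal cytotoxic concentration lies.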